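The compounds below may be only part of what the source reports. "The series", "measured", "known", "first", "only" and "open" are said of these compounds alone.

Compound 1 `CCn1c(C(=O)NCCCN(C)C)ccc1C(CC)(CC)c1ccc(OCCC(O)(CC)CC)c(C)c1`: 490 nM
Compound 2 `CCn1c(C(=O)NCCN(C)C)ccc1C(CC)(CC)c1ccc(OCCC(O)(CC)CC)c(C)c1`: 1140 nM

In a functional assay on Caco-2 cells (Homo sapiens) for antiproliferative activity, read by MTT assay, with a stated time of 48 h (a higher number here means a weaker inhibitor, a lower number a stronger inhibitor), compound 2 gives 1140 nM, the higher of the two numbers, which makes it the weaker inhibitor of the pair. Compound 3 `CCN(CC)CCNC(=O)c1ccc(C(CC)(CC)c2ccc(OCCC(O)(CC)CC)c(C)c2)n1CC` is not yet measured. It differs from compound 2 in one place: diethylamino in place of dimethylamino on a saturated chain carbon, two bonds along the chain from an amide-type nitrogen. Among the measured compounds shown here, only one measured step bears on this, and it alters the chain rather than the amine: a 2.3-fold higher number from compound 1 to compound 2 (0.37 log units; beyond the scatter). That modest step gives only a loose guide, so a similarly modest change towards a lower number is expected. The expected step is a 1.4-fold lower number from compound 2 to compound 3 (0.15 log units; within the scatter). Compound 3 is estimated at 800 nM, with an expected range of 350 nM to 1800 nM.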

Compound 3, half-maximal inhibitory concentration: 1630 nM
Compound 3: middle estimate off by 2.0-fold (0.31 log units), on the low side; the measured number falls inside the stated range.
By their numbers in this assay, from the lowest: compound 1; then compounds 2 and 3 (each within the scatter of the next).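

In this assay, diethylamino in place of dimethylamino gives a 1.4-fold higher number from compound 2 to compound 3 (0.16 log units; within the scatter), so at this position, on a saturated chain carbon two bonds along the chain from an amide-type nitrogen, ethyl groups on the amine read no differently from methyl groups. By contrast, the change that alters the chain as well as the amine gives a 3.3-fold higher number from compound 1 to compound 3 (0.52 log units; beyond the scatter), which lies beyond the scatter. No measurement here explains either step.

Still open, on these data alone, is how diethylamino reads on the longer chain of compound 1. Also open, as far as these compounds go, is how a ring amine such as piperidine or morpholine reads at this position.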